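Hydroxy to methoxy: from compound 2 to compound 4

The compounds below may be only part of what the source reports. "The series", "measured", "known", "first", "only" and "open" are said of these compounds alone.

Compound 2 `O=C(Nc1cccc(-n2cc(-c3ccncc3)c(-c3cc(O)cc(Cl)c3)n2)c1)Nc1ccc(Cl)c(Cl)c1` stands at the bottom of the three numbers measured in a functional assay on SF-539 cells (Homo sapiens) for inhibition, read by sulforhodamine B assay, with a stated time of 48 h, tested at 10 uM (on this read-out lower numbers stand for a stronger effect and higher numbers for a weaker effect at the one concentration tested), giving -29%. Among the measured compounds shown here, compound 1 `O=C(Nc1cccc(-n2cc(-c3ccncc3)c(-c3cc(O)cc(Cl)c3)n2)c1)Nc1ccc(Cl)c(C(F)(F)F)c1` gives 32.6%, and the only single-place step in the set, a number 61.6 percentage points lower from compound 1 to compound 2 (beyond the scatter), concerns a different place in the molecule from the one changed here. Compound 3 `COc1cc(Cl)cc(-c2nn(-c3cccc(NC(=O)Nc4cc(C(F)(F)F)cc(C(F)(F)F)c4)c3)cc2-c2ccncc2)c1` gives -17.7%; it differs from compound 2 in two places at once, so no single step can be read from that pair, though its number sits not far from that of compound 2.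

Compound 4 `COc1cc(Cl)cc(-c2nn(-c3cccc(NC(=O)Nc4ccc(Cl)c(Cl)c4)c3)cc2-c2ccncc2)c1` differs from compound 2 by methyl in place of hydrogen on an oxygen on an aromatic ring. For the measured compounds named here, no measured step isolates this change. The nearest pointer is compound 3, which already carries the methoxy and gives -17.7%, a number in the same low region as compound 2. On that basis little movement is expected. For compound 4 the expected step is a number 7 percentage points higher from compound 2 to compound 4 (within the scatter), giving an estimate of -22% with a range from -50% to 10%.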

Compound 4, a percentage reported as activity, at one concentration (the size of the read-out at that concentration, not a potency): 21%
Compound 4: the middle estimate sits 43 percentage points below what was measured, outside the stated range (above it).
By their numbers in this assay, from the lowest: compound 2; then compound 3; then compound 4; then compound 1.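

On the 3-chloro-5-hydroxyphenyl group, hydroxy to methoxy is not a neutral change in this assay: the read-out gives a number 50 percentage points higher from compound 2 to compound 4 (beyond the scatter), the first step read at this place in the series. Among the compounds shown here, with the rest of compound 2 kept, one added methyl on the oxygen is enough for this large step, so within this pair the free hydroxy goes with the stronger effect, and this place matters as much as the one changed in a number 61.6 percentage points lower from compound 1 to compound 2 (beyond the scatter), which is also large. No measurement at hand accounts for the step.

For the compounds shown here, whether hydroxy to methoxy gives a step of similar size with the other end of the molecule as in compound 1 remains open, as only one pair carries it. Also open, going by these compounds, is how an amine or an ethoxy group would read at this place.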